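The source may hold more compounds than are shown below. What is called first, only, known or untested is meant among the compounds shown, and "the series" means these compounds.

Compound 3 `O=C(COc1ccc2cc(/C=C3/SC(=O)NC3=O)ccc2c1)Nc1ccc(F)cc1F` is known in an assay on isolated protein for inhibition of histone deacetylase 8 (Homo sapiens), with a stated time of 1 h (on this read-out lower numbers stand for stronger inhibition and higher numbers for weaker inhibition), only as a limit, > 50000 nM (the limit of > 50000 nM in this assay, at which 1 of the 3 values shown sits). Compound 1 `COc1cccc(NC(=O)COc2ccc3cc(/C=C4/SC(=O)NC4=O)ccc3c2)c1` gives 7600 nM and compound 2 `O=C(COc1ccc2cc(/C=C3/SC(=O)NC3=O)ccc2c1)Nc1cccc(F)n1` gives 7200 nM; the step of a 1.1-fold lower number from compound 1 to compound 2 (0.02 log units; within the scatter). Against these, the steps of an at least 6.5-fold higher number from compound 1 to compound 3 (0.81 log units; beyond the scatter) and an at least 6.9-fold higher number from compound 2 to compound 3 (0.84 log units; beyond the scatter) place compound 3 at the weak end of the three. Compound 4 `O=C(COc1ccc2cc(/C=C3/SC(=O)NC3=O)ccc2c1)Nc1ccc(Br)cc1` carries 4-bromophenyl in place of 2,4-difluorophenyl on an amide-type nitrogen. Going by the values given here, no measured step covers this exchange; the two steps into compound 3 show only that 2,4-difluorophenyl on the amide-type nitrogen reads weaker than 3-methoxyphenyl or 6-fluoropyridin-2-yl. A partial return toward the level of compound 1 and compound 2 is therefore expected, as a lower number, an at least 2.5-fold lower number from compound 3 to compound 4 (0.39 log units; beyond the scatter), with wide uncertainty. Compound 4 is estimated at 20000 nM, between 5000 nM and 80000 nM.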

Compound 4, half-maximal inhibitory concentration: 16000 nM
Estimate against measurement, compound 4: 1.3-fold (0.10 log units) above, and the stated range covers the measured number.
By their numbers in this assay, from the lowest: compounds 2 and 1 (each within the scatter of the next); then compound 4. At a limit, above all of these: compound 3.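

At the amide-type nitrogen, 4-bromophenyl gives a measurable number where 2,4-difluorophenyl does not (an at least 3.1-fold lower number from compound 3 to compound 4 (0.49 log units; beyond the scatter)), so the substituents on the phenyl ring matter here, not the ring alone. Even so, 4-bromophenyl stays short of the other two groups (a 2.2-fold higher number from compound 2 to compound 4 (0.35 log units; beyond the scatter); a 2.1-fold higher number from compound 1 to compound 4 (0.32 log units; beyond the scatter)). The reading for compound 3 remains a limit, so the full size of its step is unknown: the limit of > 50000 nM in this assay, at which 1 of the 4 values shown sits.

Going by these compounds, whether an amine or a carboxylic acid on this phenyl ring would bring the number below those of compound 1 and compound 2 stays open. So does the reading of 4-chlorophenyl on the same nitrogen.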